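Aryl Amide in Place of Propyl on the Shared Core

The source may hold more compounds than are shown below. What is called first, only, known or untested is meant among the compounds shown, and "the series" means these compounds.

Measured compounds:
Compound 1 `CCCC(=O)Nc1nc2ccc(NC(=O)CSc3cccc(O)c3)cc2s1` — 10600 nM
Compound 2 `O=C(CSc1ccc2ccccc2c1)Nc1ccc2nc(NC(=O)c3ccc(C(F)(F)F)cc3)sc2c1` — 300 nM
Compound 3 `CCCC(=O)Nc1nc2ccc(NC(=O)CSc3ccc(Cl)cc3)cc2s1` — 2120 nM

In a functional assay on HCT-116 cells (Homo sapiens) for antiproliferative activity, read by MTT assay, with a stated time of 72 h (on this read-out higher numbers stand for weaker inhibition and lower numbers for stronger inhibition), compound 1 gives the highest of the three numbers. Its nearest neighbour is compound 3, reached by a 5.0-fold lower number from compound 1 to compound 3 (0.70 log units; beyond the scatter). Among the measured compounds shown here, compound 2 lies further away, but it differs from compound 1 in two places at once, one of them at the carbonyl carbon in question, so its value shows only that a low number is possible with a changed group there.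

The step to compound 4 `Cc1ccc(C(=O)Nc2nc3ccc(NC(=O)CSc4cccc(O)c4)cc3s2)cc1` makes a single change: 4-methylphenyl in place of propyl on a carbonyl carbon. For the measured compounds named here, no measured step alters this carbonyl substituent alone, so the single measured step does not bear on it directly; compound 2 points toward a lower number without settling the size. Compound 4 is therefore expected to show a modest lowering, a 3.0-fold lower number from compound 1 to compound 4 (0.48 log units; beyond the scatter), with wide uncertainty. The estimate for compound 4 in this assay is 3500 nM, between 1000 nM and 12000 nM.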

Compound 4, half-maximal inhibitory concentration: 7730 nM
Compound 4: the middle estimate sits 2.2-fold (0.34 log units) below what was measured; measured number inside the range.
By their numbers in this assay, from the lowest: compound 2; then compound 3; then compounds 4 and 1 (each within the scatter of the next).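

In this assay, a 1.4-fold lower number from compound 1 to compound 4 (0.14 log units; within the scatter), so 4-methylphenyl in place of propyl on a carbonyl carbon, which brings in a six-membered aromatic ring, leaves the two compounds indistinguishable on this read-out. Of the two single-place steps from compound 1, only the change on the sulfur, a 5.0-fold lower number from compound 1 to compound 3 (0.70 log units; beyond the scatter), lies beyond the scatter, and the carbonyl substituent has so far shown no measurable effect when it alone is changed. Nothing available offers an explanation for this result.

From the compounds shown here alone, it remains open whether the same carbonyl change would read alike in a compound carrying 4-chlorophenyl on the sulfur. Also open, going by these compounds, is how a carbonyl substituent bearing a carboxylic acid or an amine, or a longer chain such as hexyl, would fare in this assay.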